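Chloro for Fluoro on an Inactive Pair

A few compounds are considered here, and "the series" means these few. Any claim that something is new, unique, unknown or untested is made for them only; others in the source may bear on it.

The measured compounds:
compound 1, `N#CC1=C(N)Oc2c(c3nc4ccccc4nc3c3ccccc23)C12C(=O)N(Cc1cnnn1-c1ccc(N)cc1)c1ccccc12`; compound 2, `N#CC1=C(N)Oc2c(c3nc4ccccc4nc3c3ccccc23)C12C(=O)N(Cc1cnnn1-c1ccc(F)c(Cl)c1)c1ccccc12`.

In a functional assay on HepG2 cells (Homo sapiens) for antiproliferative activity, read by MTT assay, with a stated time of 48 h (on this read-out lower numbers stand for stronger inhibition and higher numbers for weaker inhibition), compound 1 gives > 50000 nM, which is a limit of the assay and not a number. In the same this assay compound 2 gives > 50000 nM, again a limit rather than a number. The step that the two limits leave unreadable from compound 1 to compound 2 therefore cannot be read. For the measured compounds named here, compound 2 thus stands at the limit of > 50000 nM in this assay, at which 2 of the 2 values shown sit, and the one other value shown beside it is likewise a limit.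

Compound 3, `N#CC1=C(N)Oc2c(c3nc4ccccc4nc3c3ccccc23)C12C(=O)N(Cc1cnnn1-c1ccc(Cl)c(Cl)c1)c1ccccc12`, has not been measured in this assay. It differs from compound 2 by chloro in place of fluoro on an aromatic carbon. Going by the values given here, no measured step bears on this change in a readable way, since the only step available is the unreadable one from compound 1 to compound 2. Both values shown sit at the limit, so the expectation for compound 3 is that it also remains at the limit, with a step that the limit leaves unreadable from compound 2 to compound 3 expected to be no step beyond the scatter. Compound 3 is estimated at 60000 nM, with a range from 20000 nM to 200000 nM.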

Compound 3, half-maximal inhibitory concentration: > 50000 nM
Compound 3 ended at the assay's limit; the forecaster's own chance of this, stated with the estimate: 85%; the middle value is on the limit's open side.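

In this assay compound 3 gives > 50000 nM, which is a limit of the assay and not a number. No step among compound 1, compound 2 and compound 3 can therefore be read, as all three sit together: the limit of > 50000 nM in this assay, at which 3 of the 3 values shown sit.

The compounds shown leave open how these three substituted phenyl groups rank against one another, and what change would bring a value within the readable range.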